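From formyl to piperidinylmethyl: a forecast for compound 4

A few compounds are considered here, and "the series" means these few. Any claim that something is new, unique, unknown or untested is made for them only; others in the source may bear on it.

Of the compounds shown here, three sharing one core have been measured in an assay on isolated protein for binding affinity to melanin-concentrating hormone receptor 1 (Homo sapiens); a lower number here means a stronger inhibitor, a higher number a weaker inhibitor. Compound 1 `CN1CCN(CCCN(c2nc3cc(Cl)c(Cl)cc3[nH]2)[C@@H]2CC[C@]3(c4cccc(C=O)c4)C[C@@H]3C2)CC1` gives 13.7 nM. Compound 2 `CN1CCN(CCCN(c2nc3cc(F)c(F)cc3[nH]2)[C@@H]2CC[C@]3(c4cccc(C=O)c4)C[C@@H]3C2)CC1`, which carries 5,6-difluoro-1H-benzimidazol-2-yl in place of 5,6-dichloro-1H-benzimidazol-2-yl on an amine nitrogen, gives 16.3 nM; that exchange, a 1.2-fold higher number from compound 1 to compound 2 (0.08 log units; within the scatter), is within the scatter. Compound 3 `CN(C)Cc1cccc([C@]23CC[C@@H](N(CCCN4CCN(C)CC4)c4nc5cc(Cl)c(Cl)cc5[nH]4)C[C@H]2C3)c1` gives 4.9 nM. Compound 2 thus shows the highest of the three numbers, close to compound 1 and set apart from compound 3.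

Compound 4 `CN1CCN(CCCN(c2nc3cc(F)c(F)cc3[nH]2)[C@@H]2CC[C@]3(c4cccc(CN5CCCCC5)c4)C[C@@H]3C2)CC1` has not yet been measured. It differs from compound 2 in one place: (piperidin-1-yl)methyl in place of formyl on an aromatic carbon. Going by the values given here, the one measured step that bears on this change is the exchange of formyl for (dimethylamino)methyl, a 2.8-fold lower number from compound 1 to compound 3 (0.45 log units; beyond the scatter), a modest move beyond the scatter. Because a 2.8-fold lower number from compound 1 to compound 3 (0.45 log units; beyond the scatter) went toward a lower number, compound 4 is expected to follow the same direction in this assay, with a step of about a 2.7-fold lower number from compound 2 to compound 4 (0.43 log units; beyond the scatter). Compound 4 is therefore estimated at 6 nM, within a range from 2.5 nM to 14 nM.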

Compound 4, inhibition constant: 405 nM
Beside the measured number, compound 4's estimate is 68-fold (1.83 log units) below it, and the stated range ends below it.
By their numbers in this assay, from the lowest: compound 3; then compounds 1 and 2 (each within the scatter of the next); then compound 4.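

Exchanging formyl for (piperidin-1-yl)methyl on this aromatic carbon gave a 25-fold higher number from compound 2 to compound 4 (1.40 log units; beyond the scatter), so in this assay this position does not accept every aminomethyl group alike. The earlier exchange of formyl for (dimethylamino)methyl went the other way, with a 2.8-fold lower number from compound 1 to compound 3 (0.45 log units; beyond the scatter), but on the 5,6-dichloro-1H-benzimidazol-2-yl compound, so the two steps differ in both the entering group and the compound that carries it. The data shown offer no measured explanation for this opposite direction.

On these data alone, it remains open whether the large step belongs to the piperidine ring itself or depends on the 5,6-difluoro-1H-benzimidazol-2-yl group, which (dimethylamino)methyl on the difluoro compound or (piperidin-1-yl)methyl on the dichloro compound would separate. Also open, as far as these compounds go, is how a smaller ring, such as (pyrrolidin-1-yl)methyl, or a ring with a second hetero atom, such as (morpholin-4-yl)methyl, would read at this position.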